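The compounds below may be only part of what the source reports. "The series", "measured", "known", "first", "only" and "open" are said of these compounds alone.

Compound 2 `COC(=O)c1cccc(-c2ccc(CSc3nc(C(C)C)nc4ccccc34)cc2)c1` is a close relative of compound 1 `CC(C)c1nc(SCc2ccc(-c3ccccc3C#N)cc2)c2ccccc2n1`; the two share one core and differ only in the aromatic ring at the far end. In an assay on isolated protein for inhibition of phosphodiesterase 7 (Homo sapiens), read by scintillation proximity assay and cAMP accumulation, with a stated time of 1 h (a higher number here means a weaker inhibitor, a lower number a stronger inhibitor), compound 1 gives only a limit, > 100000 nM. In this assay compound 2 likewise gives only a limit, > 100000 nM. Among the measured compounds shown here, the single measured step, a step that the two limits leave unreadable from compound 1 to compound 2, therefore cannot be read in size or direction, and the limit of > 100000 nM in this assay, at which 2 of the 2 values shown sit, is all that these two compounds provide. Compound 3 `CC(C)c1nc(SCc2ccc(-c3ccccc3C(=O)O)cc2)c2ccccc2n1` has not yet been measured. It arises from compound 2 by a change on the outer ring: 2-carboxyphenyl in place of 3-(methoxycarbonyl)phenyl on an aromatic carbon; in short, a 2-carboxyphenyl takes the place of a 3-(methoxycarbonyl)phenyl on an aromatic carbon, para to a large group. For the measured compounds named here, no measured step tells what such a change does here, so nothing points to a step beyond the scatter in either direction. Compound 3 is expected to stay at or near the limit, with an estimated step that the limit leaves unreadable from compound 2 to compound 3. The estimate for compound 3 is 150000 nM, with a range from 30000 nM to 1000000 nM.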

Compound 3, half-maximal inhibitory concentration: 44000 nM
For compound 3 the middle estimate is 3.4-fold (0.53 log units) above the measured one; measured number inside the range.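

In this assay, among the compounds shown here, compound 3 gives 44000 nM, the first number here that is not a limit, so the outer ring can change the read-out, although that number is still high. Replacing 3-(methoxycarbonyl)phenyl with 2-carboxyphenyl gives an at least 2.2-fold lower number from compound 2 to compound 3 (0.35 log units; beyond the scatter), while the simpler swap of carboxy for cyano, from 2-cyanophenyl to 2-carboxyphenyl, gives an at least 2.2-fold lower number from compound 1 to compound 3 (0.35 log units; beyond the scatter), which shows that changing this one group on the ring is enough for a step beyond the scatter. The true size of both steps could be larger, since neither starting compound has an exact number and each offers only a limit: the limit of > 100000 nM in this assay, at which 2 of the 3 values shown sit.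

The compounds shown leave open whether the gain needs the carboxylic acid itself or would also appear with an amide or a hydroxymethyl group in its place. They also leave open how much further this outer ring can take the number down, and whether the same group would do as well at another place on the ring.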